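Shifting a methoxy group on a hydroxamic acid inhibitor

The compounds below may be only part of what the source reports. "The series", "measured", "known", "first", "only" and "open" are said of these compounds alone.

Compound 1, `COc1cccc(C(=O)c2ccc3c(ccn3S(=O)(=O)c3cccc(/C=C/C(=O)NO)c3)c2)c1`, gives 3530 nM in an assay on isolated protein for inhibition of histone deacetylase 8 (Homo sapiens); a higher number here means a weaker inhibitor, a lower number a stronger inhibitor.
Compound 2, `O=C(NO)c1ccc(Cn2ccc3cc(C(=O)c4ccc(Cl)cc4)ccc32)cc1`, gives 1060 nM in this assay.

Within the data shown here, of the two compounds measured so far, compound 1 has the higher number, and the gap to compound 2 lies beyond the usual scatter of repeated measurements. Compound 2 is built on a different core and a different hydroxamic acid arm, so it offers no direct guide to small changes around compound 1.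

Compound 3, `COc1ccc(C(=O)c2ccc3c(ccn3S(=O)(=O)c3cccc(/C=C/C(=O)NO)c3)c2)cc1`, differs from compound 1 in one place: 4-methoxyphenyl in place of 3-methoxyphenyl on a carbonyl carbon. Both rings carry the same atoms, only joined differently. Among the measured compounds shown here, nothing among the measured compounds shows how such a shift behaves here, so the expected step from compound 1 to compound 3 is small, a 1.2-fold lower number from compound 1 to compound 3 (0.07 log units; within the scatter), within the scatter in either direction. On that basis compound 3 is estimated at 3000 nM in this assay, with a range from 1000 nM to 9000 nM.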

Compound 3, half-maximal inhibitory concentration: 812 nM
Estimate against measurement, compound 3: 3.7-fold (0.57 log units) above; measured number outside the range, below it.
By their numbers in this assay, from the lowest: compounds 3 and 2 (each within the scatter of the next); then compound 1.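

In this assay, the change gives a 4.3-fold lower number from compound 1 to compound 3 (0.64 log units; beyond the scatter), a step beyond the usual scatter. So the aryl group on this carbonyl carbon is sensitive to where its methoxy group is attached, even though 3-methoxyphenyl and 4-methoxyphenyl contain the same atoms and the same counts of hydrogen-bond donors and acceptors. Nothing measured here explains why the two arrangements differ.

On these data alone, it remains open whether an amine or a carboxylic acid in place of the methoxy group would keep the lower number seen for compound 3. As far as these compounds go, it is also open whether the same shift would have a similar effect on another core, such as that of compound 2, which differs from compound 3 in more than one place.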